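The source may report more compounds than this note shows. Statements on the series, on what has been measured and on what is new or still open speak of the compounds shown alone.

In an ADME assay on HFF-1 cells (Homo sapiens) for antiproliferative activity, read by sulforhodamine B assay, with a stated time of 2 days (on this read-out higher numbers stand for weaker inhibition of growth and lower numbers for stronger inhibition of growth), compound 1 `CC(C)c1ccc(/C=C/C(=O)NCCCCNc2ccnc3cc(Cl)ccc23)cc1` gives > 100000 nM, which is a limit of the assay rather than a measured number. Compound 2 `O=C(/C=C/c1cccc(F)c1)NCCCCNc1ccnc2cc(Cl)ccc12` in this assay gives > 100000 nM, also a limit. The change from compound 1 to compound 2 is a step that the two limits leave unreadable from compound 1 to compound 2, because both values sit at the limit of > 100000 nM in this assay, at which 2 of the 2 values shown sit. Compound 3 `O=C(/C=C/c1cccc([N+](=O)[O-])c1)NCCCCNc1ccnc2cc(Cl)ccc12` differs from compound 2 by nitro in place of fluoro on an aromatic carbon. Among the compounds with values here, no measured step speaks to this change, and the two known values are limits only. Compound 3 is therefore expected to remain near the limit, at an estimated 150000 nM spanning 60000 nM to 400000 nM, a step that the limit leaves unreadable from compound 2 to compound 3.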

Compound 3, concentration for 50% growth inhibition: > 100000 nM
Compound 3 gave a limit, no number; the forecaster's own chance of this, stated with the estimate: 85%; the middle value does not contradict the limit.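

Within the data shown here, compound 1, compound 2 and compound 3 all give a limit of the assay rather than a number, so no step among them can be read: the limit of > 100000 nM in this assay, at which 3 of the 3 values shown sit.

The compounds shown leave open how strongly each inhibits growth in this assay and whether the exchanged groups make any difference.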